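The source may hold more compounds than are shown below. What is called first, only, known or untested is meant among the compounds shown, and "the series" means these compounds.

The compounds here share one core and differ only in the groups attached to it. Compound 1, `O=C(O)/C=C/c1ccc(/C(=C(/CCF)c2ccccc2)c2ccc3[nH]ncc3c2)cc1`, in a functional assay on MCF7 cells (Homo sapiens) for cytotoxicity, read by CellTiter-Glo, with a stated time of 5 days (a lower number here means a stronger inhibitor, a higher number a weaker inhibitor), gives 2.1 nM. Compound 2, `CC/C(=C(/c1ccc(/C=C/C(=O)O)cc1)c1ccc2[nH]nc(C)c2c1)c1ccccc1`, gives in this assay only a limit, > 1000 nM, and not a number (the limit of > 1000 nM in this assay, at which 1 of the 2 values shown sits).

Compound 3, `CC/C(=C(/c1ccc(/C=C/C(=O)O)cc1)c1cc(F)c2[nH]ncc2c1)c1ccccc1`, has not yet been measured. It differs from compound 2 in one place: 7-fluoro-1H-indazol-5-yl in place of 3-methyl-1H-indazol-5-yl on a double-bonded chain carbon bound to an aromatic carbon and a double-bonded chain carbon. For the measured compounds named here, no pair of measured compounds differing in a single place is available, so this step has no measured counterpart of its own. Compound 1 carries neither the methyl nor the fluorine on that ring and a different chain elsewhere, and the two values shown for compound 1 and compound 2 alone indicate that changes to these parts of the core can span a wide range of potency.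

The step from compound 2 to compound 3 is expected to be large and toward stronger inhibition, well beyond the scatter, estimated as an at least 50-fold lower number from compound 2 to compound 3 (1.69 log units; beyond the scatter). Compound 3 is estimated to give 20 nM, with a likely range from 3 nM to 250 nM.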

Compound 3, half-maximal inhibitory concentration: 7.5 nM
The estimate for compound 3 lay 2.7-fold (0.43 log units) above the measured number; the range from low to high includes it.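

For the compounds shown here, exchanging 3-methyl-1H-indazol-5-yl for 7-fluoro-1H-indazol-5-yl gives an at least 130-fold lower number from compound 2 to compound 3 (2.12 log units; beyond the scatter) in this assay, the first step here between measured compounds that differ in one place. It shows that the group on this double-bonded chain carbon can by itself separate a compound with a measurable potency from one without, even though both groups have the same number of heavy atoms, the same two aromatic rings and the same hydrogen-bond donor and acceptor counts. The full size of the step cannot be read, because compound 2 has a limit and not a number: the limit of > 1000 nM in this assay, at which 1 of the 3 values shown sits.

The exchange removes a methyl and adds a fluorine at once, so the compounds shown cannot tell which of the two carries the step, and a partner of compound 2 with plain 1H-indazol-5-yl and nothing else changed would separate them. As far as these compounds go, how a chlorine or a methoxy group would behave in the place of that fluorine also remains open.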